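Moving a Methoxy Group: Expected Effect on Clearance

A few compounds are considered here, and "the series" means these few. Any claim that something is new, unique, unknown or untested is made for them only; others in the source may bear on it.

Of the compounds shown here, two have been measured in an ADME assay on microsomes from liver (Homo sapiens) for metabolic stability, tested at 2.5 uM; a lower number here means slower removal, a higher number faster removal of the compound. Compound 1 `COc1cccc(-c2c(S(=O)(=O)c3ccc(C)c(C)c3)cnc3cc(F)ccc23)c1` gives 8.78 mL/min in this assay. Compound 2 `COc1ccc(-c2c(S(=O)(=O)c3cc(Cl)cc(Cl)c3)cnc3cc(F)ccc23)cc1` gives 1 mL/min, the lowest of the two numbers, and compound 1 stands well above it, beyond the usual scatter. Going by the values given here, compound 3 `COc1cccc(-c2c(S(=O)(=O)c3cc(Cl)cc(Cl)c3)cnc3cc(F)ccc23)c1` has not yet been measured; it differs from compound 2 in one place: 3-methoxyphenyl in place of 4-methoxyphenyl on an aromatic carbon Compound 1 also carries 3-methoxyphenyl, but its other aryl group differs, so no measured step isolates this change. For compound 3 only a small rise, near the edge of the scatter, is expected: a 2.0-fold higher number from compound 2 to compound 3 (0.30 log units; within the scatter). The value of compound 3 is estimated at 2 mL/min, with a range from 0.7 mL/min to 6 mL/min.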

Compound 3, intrinsic clearance in a liver preparation (reported as CLH), per the amount of preparation that the assay uses: 1.51 mL/min
Compound 3: the middle estimate sits 1.3-fold (0.12 log units) above what was measured; the measured number falls inside the stated range.
By their numbers in this assay, from the lowest: compounds 2 and 3 (each within the scatter of the next); then compound 1.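

In this assay, 3-methoxyphenyl in place of 4-methoxyphenyl gives a 1.5-fold higher number from compound 2 to compound 3 (0.18 log units; within the scatter) and so moving the methoxy group on this ring makes no difference beyond the scatter. With 3-methoxyphenyl held fixed, 3,5-dichlorophenyl in place of 3,4-dimethylphenyl on the sulfonyl sulfur gives a 5.8-fold lower number from compound 1 to compound 3 (0.76 log units; beyond the scatter) and this step lies beyond the scatter. The aryl group on the sulfonyl sulfur is therefore the first change seen to shift this number clearly.

Nothing measured here explains either step. Also open, going by these compounds, is how the number would respond to a hydroxyl or an amine in place of the methoxy group.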